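Methoxy addition on the flavone ether with a naphthyl amide

A few compounds are considered here, and "the series" means these few. Any claim that something is new, unique, unknown or untested is made for them only; others in the source may bear on it.

Compound 1 `Cc1ccc(-c2c(OCC(=O)Nc3cccc4ccccc34)oc3ccccc3c2=O)cc1` opens the set, and in an ADME assay on MDCK-II cells (Canis lupus familiaris) for inhibition, read by MTT assay, with a stated time of 72 h (on this read-out lower numbers stand for stronger inhibition of growth and higher numbers for weaker inhibition of growth), compound 1 stands as "not determined" (no result reported), so no result is available for it. Compound 2 `COc1ccc(-c2c(OCC(=O)Nc3cccc4ccccc34)oc3ccccc3c2=O)cc1` gives > 100000 nM in this assay, and this is a limit of the assay rather than a number. Compound 2 therefore sits at the limit of > 100000 nM in this assay, at which 1 of the 3 values shown sits. For the measured compounds named here, compound 3 `COc1ccc(NC(=O)COc2ccc(C(=O)/C=C/c3c(F)cccc3F)cc2)cc1OC`, built on a different core, gives 36200 nM in this assay; compound 2 and compound 3 share no one-place step, so the two values can only be set side by side without a computed difference between them. Compound 4 `COc1ccc(-c2c(OCC(=O)Nc3cccc4ccccc34)oc3ccccc3c2=O)cc1OC` is yet to be measured in this assay. Compound 4 differs from compound 2 by methoxy in place of hydrogen on an aromatic carbon. Going by the values given here, no step between measured compounds is available to size this change. For compound 4 the methoxy in place of hydrogen on an aromatic carbon is expected to move the read-out little beyond the scatter, and a limit is again expected to be the likely outcome. The estimate for compound 4 is 110000 nM, within 35000 nM to 350000 nM, which corresponds to an expected step that the limit leaves unreadable from compound 2 to compound 4.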

Compound 4, concentration for 50% growth inhibition: > 100000 nM
Compound 4 gave a limit, no number; the forecaster's own chance of this, stated with the estimate: 60%; the middle value does not contradict the limit.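

Compound 2 and compound 4 both stand at a limit of the assay and not at a number, so the step from 4-methoxyphenyl to 3,4-dimethoxyphenyl cannot be read. The compounds shown leave open whether this methoxy in place of hydrogen shifts growth inhibition on the shared core at all.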